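A chloro substituent on the anilino ring

The source may hold more compounds than are shown below. What is called first, only, known or untested is meant among the compounds shown, and "the series" means these compounds.

Compound 1 `COC(=O)c1c(Nc2ccccc2)sc(C(=O)c2ccc(OC)cc2)c1C` gives 63% in a functional assay, with a stated time of 150 min, tested at 35 ug/mL; on this read-out lower numbers stand for a weaker effect and higher numbers for a stronger effect at the one concentration tested.
Compound 2 `COC(=O)c1c(Nc2ccccc2)sc(C(=O)c2ccc(C)cc2)c1C` gives 10.3% in this assay.

Of the two numbers shown, compound 2 holds the lowest. Among the compounds with values here, its nearest neighbour is compound 1, and the one measured step, a number 52.7 percentage points lower from compound 1 to compound 2 (beyond the scatter), is what separates them; that step is a change on the ring attached to the carbonyl.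

Compound 3 `COC(=O)c1c(Nc2ccc(Cl)cc2)sc(C(=O)c2ccc(C)cc2)c1C` has not yet been measured in this assay. It differs from compound 2 by chloro in place of hydrogen on an aromatic carbon. Within the data shown here, the single measured step, a number 52.7 percentage points lower from compound 1 to compound 2 (beyond the scatter), concerns a different ring from the one that receives the chloro, so no measured step bears on this change, and the data give no direction for it. In the absence of any comparable step, the expectation for compound 3 is a step of no size beyond the scatter, a number 1.7 percentage points higher from compound 2 to compound 3 (within the scatter), with a wide allowance either way. Compound 3 is accordingly estimated at 12% in this assay, with a range from 2% to 32%.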

Compound 3, a percentage reported as activity, at one concentration (the size of the read-out at that concentration, not a potency): "not active" (no number reported)
Compound 3: no number reported, so the estimate cannot be set against anything.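

In this assay, within the data shown here, compound 3 gives "not active" (no number reported), so no step from compound 2 to compound 3 can be read. The compounds shown leave open how far chloro in place of hydrogen on the anilino ring moves the read-out, and in which direction. No supporting evidence bears on this result.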